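Three Aryl Thioethers Measured, a Fourth Awaits

The compounds below may be only part of what the source reports. "The series", "measured", "known", "first", "only" and "open" are said of these compounds alone.

The series shares one core, seen in compound 1 `Cc1ccc(CS/C(=C/c2ccc(C)s2)C(=O)c2ccc(Cl)cc2)cc1`, and varies only the aryl group on a double-bonded chain carbon bound to a double-bonded chain carbon. In a functional assay on DU-145 cells (Homo sapiens) for inhibition, read by trypan blue exclusion, with a stated time of 96 h (a higher number here means a weaker inhibitor of growth, a lower number a stronger inhibitor of growth), compound 1 gives 50000 nM. Compound 2 `Cc1ccc(CS/C(=C/c2ccccc2F)C(=O)c2ccc(Cl)cc2)cc1`, carrying 2-fluorophenyl there, gives 10000 nM in this assay, so that a 5.0-fold lower number from compound 1 to compound 2 (0.70 log units; beyond the scatter). Compound 3 `Cc1ccc(CS/C(=C/c2cccc(Cl)c2Cl)C(=O)c2ccc(Cl)cc2)cc1`, with 2,3-dichlorophenyl, gives 25000 nM, and a 2.0-fold lower number from compound 1 to compound 3 (0.30 log units; within the scatter) while a 2.5-fold higher number from compound 2 to compound 3 (0.40 log units; beyond the scatter). Among the three numbers compound 3 stands second highest, nearest to compound 1 and furthest from compound 2.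

Compound 4 `Cc1ccc(CS/C(=C/c2cc(C)ccc2C)C(=O)c2ccc(Cl)cc2)cc1` has not yet been measured. Its change from compound 3 is 2,5-dimethylphenyl in place of 2,3-dichlorophenyl on a double-bonded chain carbon bound to a double-bonded chain carbon. Both measured steps that swap one aryl group for another bear on it: the step from compound 1 to compound 2 was modest and beyond the scatter, and the step from compound 2 to compound 3 was modest as well, while the step from compound 1 to compound 3 stayed within the scatter. All three aryl changes so far moved the number by only small or modest amounts, so the change to compound 4 is expected to give at most a modest step in either direction, and most likely none beyond the scatter, in this assay. Compound 4 is therefore estimated at 20000 nM, with a range from 7000 nM to 60000 nM, which means an expected 1.3-fold lower number from compound 3 to compound 4 (0.10 log units; within the scatter).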

Compound 4, concentration for 50% growth inhibition: 10000 nM
For compound 4 the middle estimate is 2.0-fold (0.30 log units) above the measured one; the range from low to high includes it.
By their numbers in this assay, from the lowest: compounds 2 and 4 (each within the scatter of the next); then compounds 3 and 1 (each within the scatter of the next).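

The result shows that this position does not depend on a halogen on the phenyl ring: 2,5-dimethylphenyl, with 8 heavy atoms, all carbon, replaces 2,3-dichlorophenyl, with the same heavy-atom count, and gives a 2.5-fold lower number from compound 3 to compound 4 (0.40 log units; beyond the scatter) in this assay. Two quite different substituted phenyl groups also prove indistinguishable here, since 2,5-dimethylphenyl in place of 2-fluorophenyl gives no change at the digits printed from compound 2 to compound 4 (within the scatter), and the replacement of 5-methylthiophen-2-yl by 2,5-dimethylphenyl gives a 5.0-fold lower number from compound 1 to compound 4 (0.70 log units; beyond the scatter), matching the earlier 5.0-fold lower number from compound 1 to compound 2 (0.70 log units; beyond the scatter), while compound 3 goes against any general gain from a phenyl group at this place, with a 2.0-fold lower number from compound 1 to compound 3 (0.30 log units; within the scatter). No evidence is available to explain why the 2,3-dichlorophenyl group stands apart from the other two phenyl groups.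

Compound 2 gives 10000 nM. The compounds shown leave open whether any group at this place can bring the number much further down, for instance a phenyl ring carrying an amine or a carboxylic acid. With the rest of the shared core held constant throughout, they also leave open whether the same order of aryl groups would hold if the sulfur-bound benzyl group gave way to a longer chain.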